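The source may report more compounds than this note shows. Statements on the series, on what has been measured and on what is new or still open speak of the compounds shown alone.

Within the data shown here, in a functional assay on HeLa cells (Homo sapiens) for inhibition, read by MTT assay, with a stated time of 72 h (a lower number here means a stronger inhibitor, a higher number a weaker inhibitor), only two compounds have been measured so far. Compound 1 `COc1cc(O)cc(O)c1C(=O)/C=C/c1ccc(C)cc1` gives > 50000 nM as a limit of the assay and not as a number. Among the measured compounds shown here, compound 2 `COc1cc(OC)c(C(=O)/C=C/c2ccc(O)c(O)c2)c(OC)c1` gives 15800 nM as the only actual number, so it has no measured number to be ranked against. Compound 3 `COc1cc(OC)c(C(=O)/C=C/c2ccc(Cl)cc2)c(OC)c1` is the next to be measured. The change 4-chlorophenyl in place of 3,4-dihydroxyphenyl on a double-bonded chain carbon bound to a double-bonded chain carbon puts 4-chlorophenyl in place of 3,4-dihydroxyphenyl on a double-bonded chain carbon bound to a double-bonded chain carbon. For the measured compounds named here, no measured step between closely matched compounds is available to size this change, so the expectation starts from compound 2 at 15800 nM in this assay and leans in neither direction. The expected step of a 1.1-fold lower number from compound 2 to compound 3 (0.05 log units; within the scatter) stays within the usual scatter. Compound 3 is estimated at 14000 nM and is expected to fall from 4000 nM to 50000 nM when measured.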

Compound 3, half-maximal inhibitory concentration: 3900 nM
The estimate for compound 3 lay 3.6-fold (0.56 log units) above the measured number, and the stated range ends above it.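

In this assay, among these compounds, 4-chlorophenyl in place of 3,4-dihydroxyphenyl gives a 4.1-fold lower number from compound 2 to compound 3 (0.61 log units; beyond the scatter), the first sized change on a double-bonded chain carbon bound to a double-bonded chain carbon. It shows that the number at this place responds to the aryl group, and that the 3,4-dihydroxyphenyl group with its hydrogen-bond donors is not needed for activity here, since compound 3 has none on the entering group. Nothing measured here accounts for the step.

Among the compounds shown here, the single swap removes both hydroxyl groups and adds a chlorine at once, so it remains open which of these changes carries the step. As far as these compounds go, an unsubstituted phenyl, a 4-hydroxyphenyl or a 4-aminophenyl at this place could separate the two, and whether fluorine or bromine would read like chlorine also stays open.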